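The source may hold more compounds than are shown below. What is called first, only, known or untested is meant among the compounds shown, and "the series" means these compounds.

In a functional assay on HCT-116 cells (Homo sapiens) for inhibition, read by MTT assay, with a stated time of 2 days (a higher number here means a weaker inhibitor of growth, a lower number a stronger inhibitor of growth), compound 2 (`Nc1ccccc1NC(=O)c1ccc(NCC(=O)Nc2ccc([N+](=O)[O-])cc2)cc1`) gives 600 nM and is the lowest of the three measured numbers, with compound 1 (`Nc1ccccc1NC(=O)CCCNCC(=O)Nc1cccc(Cl)c1`) at 11600 nM and compound 3 (`Nc1ccccc1NC(=O)CCCNCC(=O)Nc1cc(Cl)ccc1Cl`) at 31000 nM on a core other than that of compound 2. Compound 4 (`COc1ccc(NC(=O)CNc2ccc(C(=O)Nc3ccccc3N)cc2)cc1`) carries methoxy in place of nitro on an aromatic carbon, para to a large group (methoxy in place of nitro on an aromatic carbon). Among the compounds with values here, no measured step makes this exchange. The nearest evidence is chloro in place of hydrogen on an aromatic carbon (a 2.7-fold higher number from compound 1 to compound 3 (0.43 log units; beyond the scatter)), a modest step beyond the scatter that bears only loosely. A similarly modest rise is expected in this assay, though the direction is held weakly. The estimated step is (a 1.5-fold higher number from compound 2 to compound 4 (0.18 log units; within the scatter)). For compound 4 the expected value is 900 nM within a range from 300 nM to 2700 nM.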

Compound 4, concentration for 50% growth inhibition: 7500 nM
The estimate for compound 4 lay 8.3-fold (0.92 log units) below the measured number; measured number outside the range, above it.
By their numbers in this assay, from the lowest: compound 2; then compounds 4 and 1 (each within the scatter of the next); then compound 3.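

In this assay, the exchange of nitro for methoxy on the aromatic carbon para to a large group is a large step (a 13-fold higher number from compound 2 to compound 4 (1.10 log units; beyond the scatter)), so the number on the core of compound 2 responds strongly to the group at this place. That step is larger than the modest chloro step on the other core (a 2.7-fold higher number from compound 1 to compound 3 (0.43 log units; beyond the scatter)). Nothing available explains its size.

Still open, on these data alone, is whether the lower number follows nitro specifically, which an amine or a carboxylic acid at this place would help decide. Also open, as far as these compounds go, is whether the same exchange on the core of compound 1 gives a step of similar size.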